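A few compounds are considered here, and "the series" means these few. Any claim that something is new, unique, unknown or untested is made for them only; others in the source may bear on it.

Going by the values given here, compound 2 `CCOc1ccc2c(=O)c(-c3ccc(O)cc3)coc2c1` gives 80 nM in an assay (Cricetulus griseus) for inhibition of aldehyde dehydrogenase, mitochondrial (Homo sapiens); on this read-out higher numbers stand for weaker inhibition and lower numbers for stronger inhibition; it is the only number among the values shown. Among the compounds with values here, compound 1 `O=C(O)COc1ccc(-c2coc3cc(OCC(=O)O)ccc3c2=O)cc1` sits at a limit of this assay, >> 9000 nM, which is not a number, and it is the one value that rests at the limit of >> 9000 nM in this assay, at which 1 of the 2 values shown sits. Compound 3 `C=CCOc1ccc2c(=O)c(-c3ccc(O)cc3)coc2c1` has not been measured; it differs from compound 2 by vinyl in place of methyl on a saturated chain carbon bound to an oxygen on an aromatic ring. Within the data shown here, no measured pair shows the effect of such a change, so the step of a 1.3-fold higher number from compound 2 to compound 3 (0.10 log units; within the scatter) is expected to stay within the usual scatter, in no clear direction. Compound 3 is expected to give 100 nM, in the range 30 nM to 300 nM.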

Compound 3, half-maximal inhibitory concentration: 180 nM
For compound 3 the middle estimate is 1.8-fold (0.26 log units) below the measured one; the measured number falls inside the stated range.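

Going by these compounds alone, replacing ethoxy with allyloxy gives a 2.3-fold higher number from compound 2 to compound 3 (0.35 log units; beyond the scatter) in this assay, the first measured step at this position. It shows that the position responds to a small change in the chain, though only modestly, with inhibition still in place. Nothing shown accounts for this step.

On these data alone, whether the extra carbon or the double bond drives the step stays open, and a saturated propoxy chain would separate the two. As far as these compounds go, how an amine or a carboxylic acid at the end of this chain would read is also open.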